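The source may hold more compounds than are shown below. What is called first, only, known or untested is meant among the compounds shown, and "the series" means these compounds.

In a functional assay on SNB-75 cells (Homo sapiens) for inhibition, read by sulforhodamine B assay, with a stated time of 48 h, tested at 10 uM (on this read-out lower numbers stand for less inhibition of growth and higher numbers for more inhibition of growth at the one concentration tested), compound 1 `COc1ccc(-c2nc3sc(-c4ccccc4)cn3n2)cc1` gives 34%. Within the data shown here, the only other measured compound, compound 2 `COc1cc(-c2nc(N)n(CC(=O)Nc3ccc(/C(C)=N\O)cc3)n2)cc(OC)c1OC`, gives 25.9%. These two numbers lie within the usual scatter of repeated measurements, so they cannot be told apart, even though compound 1 has the higher reading and the two structures differ widely. Both readings show only partial inhibition of growth at the concentration tested.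

The next compound, compound 3 `c1ccc(-c2nc3sc(-c4ccccc4)cn3n2)cc1`, keeps the core of compound 1 and changes in one place: hydrogen in place of methoxy on an aromatic carbon, (hydrogen in place of methoxy on an aromatic carbon). Among the measured compounds shown here, no two measured compounds differ by a single change, so the data offer no direct guide to what this replacement does. For the measured compounds named here, with no measured step to draw on, the expectation in this assay is no step beyond the scatter, perhaps with a small drop, and it starts from compound 1 at 34%. The estimated change is a number 4 percentage points lower from compound 1 to compound 3 (within the scatter). For compound 3, the estimated value is 30%, with an expected range of 12% to 48%.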

Compound 3, percent growth inhibition at one concentration: 15%
Compound 3: the middle estimate sits 15 percentage points above what was measured; the range from low to high includes it.
By their numbers in this assay, from the lowest: compound 3; then compounds 2 and 1 (each within the scatter of the next).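

In this assay, among these compounds, the reading is a number 19 percentage points lower from compound 1 to compound 3 (beyond the scatter) when methoxy gives way to hydrogen, and this is the first change in a single place that can be read. It shows that, on this six-membered aromatic ring of carbon only, para to a large group, the substituent matters: with the core held constant, the compound bearing methoxy inhibits growth more at the one concentration tested than the one bearing only hydrogen. Nothing measured here accounts for the drop, so the data show that the reading changes but not what lies behind that change.

As far as these compounds go, what remains open is how much of the methoxy group is needed, since one replacement at one place cannot separate the contribution of its oxygen from that of its carbon. A hydroxyl group, an amine or a longer chain such as ethoxy at this same place could show whether the reading stays near that of compound 1, falls towards that of compound 3 or goes beyond both, and whether the same holds on other cores is also unknown.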